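The compounds below may be only part of what the source reports. "The series", "measured", "known", "first", "only" and "open" are said of these compounds alone.

Measured compounds:
compound 1, `COc1ccc(S(=O)(=O)c2cc3cnc(Nc4ccc5[nH]ccc5c4)nc3n(C)c2=O)cc1`, gives 300 nM in a functional assay on K562 cells (Homo sapiens) for inhibition, read by trypan blue exclusion, with a stated time of 72 h; on this read-out lower numbers stand for stronger inhibition and higher numbers for weaker inhibition;
compound 2, `Cn1c(=O)c(S(=O)(=O)c2ccc(F)cc2N)cc2cnc(Nc3ccc4[nH]ccc4c3)nc21`, gives 2000 nM;
compound 3, `Cn1c(=O)c(S(=O)(=O)c2ccc(Br)cc2)cc2cnc(Nc3ccc4[nH]ccc4c3)nc21`, gives 5000 nM.

Compound 3 holds the highest number of the three. Its nearest neighbour is reached by a 2.5-fold higher number from compound 2 to compound 3 (0.40 log units; beyond the scatter), its furthest by a 17-fold higher number from compound 1 to compound 3 (1.22 log units; beyond the scatter), both steps beyond the scatter.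

Compound 4, `Cn1c(=O)c(S(=O)(=O)c2ccc(N)cc2F)cc2cnc(Nc3ccc4[nH]ccc4c3)nc21`, differs from compound 3 as follows: 4-amino-2-fluorophenyl in place of 4-bromophenyl on a sulfonyl sulfur. The entering group carries the same amino and fluoro substituents as the 2-amino-4-fluorophenyl of compound 2, though not in the same arrangement, so the step bearing most directly on it is a 2.5-fold higher number from compound 2 to compound 3 (0.40 log units; beyond the scatter), taken in reverse. The step of a 17-fold higher number from compound 1 to compound 3 (1.22 log units; beyond the scatter) shows that exchanging the bromo on this ring for another group can move the number a good deal. A modest drop is therefore expected, close to a 3.3-fold lower number from compound 3 to compound 4 (0.52 log units; beyond the scatter). Compound 4 is estimated at 1500 nM, within a range from 500 nM to 5000 nM.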

Compound 4, half-maximal inhibitory concentration: 1500 nM
Estimate against measurement, compound 4: no gap at the digits printed; the measured number falls inside the stated range.
By their numbers in this assay, from the lowest: compound 1; then compounds 4 and 2 (each within the scatter of the next); then compound 3.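

In this assay, 4-amino-2-fluorophenyl in place of 4-bromophenyl on the sulfonyl sulfur gives a 3.3-fold lower number from compound 3 to compound 4 (0.52 log units; beyond the scatter), so a second ring carrying amino and fluoro substituents also stands apart from the bromo ring. The two arrangements of these substituents are not told apart, at a 1.3-fold lower number from compound 2 to compound 4 (0.12 log units; within the scatter), while the 4-methoxyphenyl ring remains ahead of this one, at a 5.0-fold higher number from compound 1 to compound 4 (0.70 log units; beyond the scatter). Nothing available here explains these differences.

Which of the two substituents carries the difference from the bromo ring stays open, since a 4-aminophenyl or a 4-fluorophenyl ring would separate them. Also open, as far as these compounds go, is how a 4-hydroxyphenyl or 4-ethoxyphenyl ring, or a saturated amine such as piperidine on the sulfonyl sulfur, would compare with the 4-methoxyphenyl ring.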